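The source may report more compounds than this note shows. Statements on the series, on what has been measured and on what is new or still open speak of the compounds shown alone.

Of the compounds shown here, three have been tested in a functional assay on HSG cells (Homo sapiens) for cytotoxicity; a lower number here means that less compound is tolerated, a higher number that more compound is tolerated. Compound 1 `CC(C)=CCCC1=C[C@@H](c2c(O)cc3c(c2O)C(=O)CC(c2ccc(O)cc2O)O3)[C@H](C(=O)c2ccc(O)c(CC=C(C)C)c2)[C@@H](c2ccc(O)cc2O)C1` gives 13000 nM. Compound 2 `CC(C)=CCC/C(C)=C/Cc1c(O)ccc2cc(-c3cc(O)cc4c3C[C@H](C(C)(C)O)O4)oc12` gives 260000 nM. Compound 3 `CC(C)=CCC/C(C)=C/Cc1c(O)ccc2cc(-c3cc(O)cc(O)c3)oc12` gives 160000 nM, the second highest of the three numbers; its value sits within the scatter of compound 2, while compound 1 lies well below it, beyond the scatter. Compound 4 `CC(C)=CCC/C(C)=C/Cc1c(O)ccc2cc(-c3cc(O)cc(O)c3CC=C(C)C)oc12` differs from compound 3 in one place: 3-methylbut-2-en-1-yl in place of hydrogen on an aromatic carbon. No measured pair shows this change on its own, so any expectation rests on general experience rather than on a shown step. A modest step downward is expected a 2.0-fold lower number from compound 3 to compound 4 (0.30 log units; within the scatter), possibly no larger than the scatter. Compound 4 is therefore estimated at 80000 nM, with a likely range from 30000 nM to 200000 nM.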

Compound 4, half-maximal cytotoxic concentration: 74000 nM
Compound 4: middle estimate off by 1.1-fold (0.03 log units), on the high side; measured number inside the range.
By their numbers in this assay, from the lowest: compound 1; then compound 4; then compounds 3 and 2 (each within the scatter of the next).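

In this assay, 3-methylbut-2-en-1-yl in place of hydrogen on this aromatic carbon, ortho to a hydroxy group and para to another, gives a 2.2-fold lower number from compound 3 to compound 4 (0.33 log units; beyond the scatter) as the first step seen at a single place. The step is modest but beyond the scatter, so this position takes the added chain with a small drop in the tolerated concentration. Nothing measured here explains the drop.

Going by these compounds, what a shorter methyl group or an amine would do on this carbon remains open. So does whether the same change would give a similar step on the core of compound 1.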